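This account rests on a few compounds, and the source may have more. Where it says the series, first, only, none or still open, it means among the compounds named here.

Two compounds of this series carry a number in a functional assay on the whole organism (strain CD1) with Mus musculus as the target, with a stated time of 0.5 h; a lower number here means that less compound is needed, a higher number that more compound is needed for the effect. Compound 1 `CC1CC(=O)N(CC(=O)N2CCN(c3ccccc3)CC2)C1=O` gives 300 mg/kg in this assay. For the measured compounds named here, compound 2 `Cc1ccccc1N1CCN(C(=O)CN2C(=O)CC(C)C2=O)CC1` gives 100 mg/kg in this assay, the lowest of the two numbers, with compound 1 as its only neighbour. Going by the values given here, the single measured step, a 3.0-fold lower number from compound 1 to compound 2 (0.48 log units; beyond the scatter), arises from a methyl in place of hydrogen on an aromatic carbon.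

Compound 3 `CC1CC(=O)N(CC(=O)N2CCN(c3ccc(Cl)c(Cl)c3)CC2)C1=O` is not yet measured in this assay. It differs from compound 2 in one place: 3,4-dichlorophenyl in place of 2-methylphenyl on an amine nitrogen in a ring. Among the compounds with values here, no measured step shows a chlorine entering the aromatic ring, so the one step on record bears only loosely on this change: it shows that altering the substituent on that ring moved the number in this assay by a modest amount, and nothing more. Within the data shown here, the change is larger in kind than the one step recorded, so the expected step of no change at the digits printed from compound 2 to compound 3 (within the scatter) is taken as no more than modest, in either direction, and may lie within the scatter. Compound 3 is therefore estimated at 100 mg/kg in this assay, with a range from 30 mg/kg to 300 mg/kg.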

Compound 3, minimum effective dose: 100 mg/kg
For compound 3 middle estimate and measured number coincide at the digits printed, and the stated range covers the measured number.
By their numbers in this assay, from the lowest: compounds 2 and 3 (each within the scatter of the next); then compound 1.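

Working notes: in this assay, the position on the amine nitrogen in a ring now has a second substituted phenyl group, and 3,4-dichlorophenyl in place of 2-methylphenyl gives no change at the digits printed from compound 2 to compound 3 (within the scatter), so these two groups cannot be told apart here despite their different substituents. Against the plain phenyl group, 3,4-dichlorophenyl gives a 3.0-fold lower number from compound 1 to compound 3 (0.48 log units; beyond the scatter), a step of the same size as a 3.0-fold lower number from compound 1 to compound 2 (0.48 log units; beyond the scatter) seen earlier, so among these three compounds both substituted phenyl groups stand apart from phenyl, with no compound going against this. No evidence is available on the origin of these steps.

From the compounds shown here alone, whether one chlorine alone, a methoxy group, a trifluoromethyl group or a pyridine ring in place of the phenyl ring would give a number in line with compound 2 and compound 3 remains open. Also open, going by these compounds, is how far this reading carries to the rest of the shared core, for example with hydrogen or an ethyl group in place of its methyl group.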